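Swapping a Carbon Ring for Methoxy on the Amide Chain

The source may report more compounds than this note shows. Statements on the series, on what has been measured and on what is new or still open speak of the compounds shown alone.

Compound 1, `C/C=C/C(=O)Nc1c(C(O)(C(F)(F)F)C(F)(F)F)ccc2ccccc12`: 72 nM
Compound 2, `O=C(CC1CCCC1)Nc1c(C(O)(C(F)(F)F)C(F)(F)F)ccc2ccccc12`: 81 nM

Both measured compounds share the same core and differ only in the group on the carbonyl carbon of the amide. In an assay on LtK cells with ATP-sensitive inward rectifier potassium channel 11 (Homo sapiens) as the target (a higher number here means that more compound is needed for the effect, a lower number that less compound is needed), compound 1 gives 72 nM. In this assay compound 2 gives 81 nM. The two numbers sit within the scatter of each other, as the step of a 1.1-fold higher number from compound 1 to compound 2 (0.05 log units; within the scatter) shows, so neither compound can be called the more or less potent one.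

Compound 3, `COCC(=O)Nc1c(C(O)(C(F)(F)F)C(F)(F)F)ccc2ccccc12`, keeps the same core and the same amide but carries a smaller, oxygen-containing group: methoxy in place of cyclopentyl on a saturated chain carbon bound to a carbonyl carbon. Among the measured compounds shown here, the only measured step bears on it indirectly. It shows that exchanging one carbon-only group for another on the carbonyl carbon moved the number very little. For the measured compounds named here, no measured compound carries an oxygen in this chain, so the effect of the methoxy group itself is untested. The reasonable expectation is a step of roughly a 1.5-fold higher number from compound 2 to compound 3 (0.17 log units; within the scatter), within the scatter or only slightly beyond it. Compound 3 is therefore estimated at 120 nM in this assay, with a range from 45 nM to 320 nM.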

Compound 3, half-maximal effective concentration: 213 nM
Compound 3: middle estimate off by 1.8-fold (0.25 log units), on the low side, within the range that was stated.
By their numbers in this assay, from the lowest: compounds 1 and 2 (each within the scatter of the next); then compound 3.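

Until now, the group on the carbonyl carbon seemed to matter little, since the two carbon-only groups of compound 1 and compound 2 gave numbers within the scatter of each other in this assay. Methoxymethyl is the first group here to move the number beyond the scatter, with a 2.6-fold higher number from compound 2 to compound 3 (0.42 log units; beyond the scatter) and a 3.0-fold higher number from compound 1 to compound 3 (0.47 log units; beyond the scatter), both modest steps towards needing more compound, so this place does respond to what it carries. The change from cyclopentyl to methoxy takes away a ring and five carbon atoms and brings in an oxygen that counts as one hydrogen-bond acceptor, and nothing available explains which of these differences matters or how it acts.

Going by these compounds, what stays open is whether the loss of the ring or the arrival of the oxygen accounts for the step. Propyl in place of methoxymethyl would keep an open chain without the oxygen, while cyclopentyloxymethyl would keep the ring and add the oxygen, so the two together could pull these effects apart.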